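The compounds below may be only part of what the source reports. "The series", "measured", "known", "first", "only" and "open" are said of these compounds alone.

In a functional assay on SNU-638 cells (Homo sapiens) for antiproliferative activity, read by sulforhodamine B assay, with a stated time of 72 h (on this read-out lower numbers stand for stronger inhibition and higher numbers for weaker inhibition), compound 3 (`CCCCS(=O)(=O)Nc1cc(-c2ccc3c(c2)N(CCCN(C)C)C(=O)CO3)cnc1OC`) gives 8970 nM. Compound 2 (`CCCCS(=O)(=O)Nc1cc(-c2ccc3c(c2)N(CCCN(CC)CC)C(=O)CO3)cnc1OC`) gives 17600 nM, and compound 1 (`COc1ncc(-c2ccc3c(c2)N(CCC(=O)N2CCOCC2)C(=O)CO3)cc1NS(=O)(=O)c1ccc(F)cc1F`) gives 5770 nM. Compound 3 stands within the scatter of each of the other two, so its number does not set it apart from either.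

The next compound to consider is compound 4 (`CCCCS(=O)(=O)Nc1cc(-c2ccc3c(c2)N(CCC(=O)N2CCOCC2)C(=O)CO3)cnc1OC`). Its difference from compound 3 is (morpholin-4-yl)carbonyl in place of (dimethylamino)methyl on a saturated chain carbon, two bonds along the chain from an amide-type nitrogen in a ring. In words, (morpholin-4-yl)carbonyl takes the place of (dimethylamino)methyl on a saturated chain carbon, two bonds along the chain from an amide-type nitrogen in a ring.

For the measured compounds named here, only one measured step touches this part of the molecule: a 2.0-fold lower number from compound 2 to compound 3 (0.29 log units; within the scatter). That step stays within the scatter, but it alters only the amino group and does not test its replacement. Going by the values given here, compound 1 already carries the entering 2-((morpholin-4-yl)carbonyl)ethyl chain and gives 5770 nM, but it also differs from compound 4 elsewhere, and no step between the two is available.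

On this limited evidence, no change beyond the scatter is expected in this assay. The expected step is a 1.3-fold lower number from compound 3 to compound 4 (0.11 log units; within the scatter). The estimate for compound 4 is 7000 nM, with an expected range of 3000 nM to 16000 nM.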

Compound 4, half-maximal inhibitory concentration: 41900 nM
For compound 4 the middle estimate is 6.0-fold (0.78 log units) below the measured one; measured number outside the range, above it.
By their numbers in this assay, from the lowest: compounds 1, 3 and 2 (each within the scatter of the next, the first and the last beyond it); then compound 4.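

In this assay, the step from the dimethylamino to the diethylamino end of the chain had stayed within the scatter, but this position does respond when (morpholin-4-yl)carbonyl enters: the change gives a 4.7-fold higher number from compound 3 to compound 4 (0.67 log units; beyond the scatter) and, against the (diethylamino)methyl group, a 2.4-fold higher number from compound 2 to compound 4 (0.38 log units; beyond the scatter). For the compounds shown here, with the (morpholin-4-yl)carbonyl chain held constant, butyl in place of 2,4-difluorophenyl on the sulfonyl sulfur gives a 7.3-fold higher number from compound 1 to compound 4 (0.86 log units; beyond the scatter), so the group on the sulfonyl sulfur also counts in this assay, a point the earlier compounds could not show. Nothing among the data shown explains either change.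

The compounds shown do not separate the carbonyl from the morpholine ring, so a 3-(morpholin-4-yl)propyl chain or a simple dimethylamide on the same chain would be needed to show which part goes with the higher number. The 2,4-difluorophenyl group appears here only with the (morpholin-4-yl)carbonyl chain, which leaves open whether the sulfonyl step would hold with a dimethylamino or diethylamino chain end.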